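A Ring Swap at the Limit of the Assay

The compounds below may be only part of what the source reports. "The series", "measured", "known", "first", "only" and "open" are said of these compounds alone.

In an ADME assay on NCM460 cells (Homo sapiens) for cytotoxicity, read by CCK-8 assay, with a stated time of 48 h (a lower number here means a stronger inhibitor, a higher number a weaker inhibitor), compound 1 `COc1ccc(/C=C\c2cc(OC)c(OC)c(OC)c2)cc1OCc1ccc(C=O)cc1`, which carries a formyl group, gives 41000 nM. Compound 2 `COc1ccc(/C=C\c2cc(OC)c(OC)c(OC)c2)cc1OCc1ccc(CN2C[C@H](O)C[C@@H]2C(=O)O)cc1` has (2-carboxy-4-hydroxypyrrolidin-1-yl)methyl in place of that formyl. Compound 2 reads > 50000 nM, which is a limit of the assay and not a number.

Compound 3 `COc1ccc(/C=C\c2cc(OC)c(OC)c(OC)c2)cc1OCc1ccc(CN2CCCC[C@H]2C(=O)O)cc1` keeps the core of compound 2 and differs in one group: 2-carboxypiperidin-1-yl in place of 2-carboxy-4-hydroxypyrrolidin-1-yl on a saturated chain carbon bound to an aromatic carbon. Put simply, 2-carboxypiperidin-1-yl stands in place of 2-carboxy-4-hydroxypyrrolidin-1-yl on a saturated chain carbon bound to an aromatic carbon.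

Among the measured compounds shown here, only one measured step bears on this change, and it replaced formyl rather than exchanging one carboxy-bearing group for another. That step is an at least 1.2-fold higher number from compound 1 to compound 2 (0.08 log units; that floor lies within the scatter). The expectation for this assay therefore rests on that step and on compound 1 at 41000 nM, and no step beyond the scatter is expected. The estimated step is a number no higher from compound 2 to compound 3 (the limit leaves the size open). For compound 3 the expected value is 50000 nM, with an estimated range of 28000 nM to 90000 nM.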

Compound 3, half-maximal inhibitory concentration: > 50000 nM
Compound 3: a limit, no number; the forecaster's own chance of this, stated with the estimate: 70%; the middle value lies on the limit itself.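

In this assay compound 3 reads > 50000 nM, which is a limit of the assay and not a number, so 2-carboxypiperidin-1-yl, on a saturated chain carbon bound to an aromatic carbon, joins 2-carboxy-4-hydroxypyrrolidin-1-yl as a second ring group carrying a carboxy group that gives no readable value. Set against the formyl group, the new group gives an at least 1.2-fold higher number from compound 1 to compound 3 (0.08 log units; that floor lies within the scatter), so this comparison offers only a floor and no measured size. The exchange of one ring group for the other cannot be read, because both results stop at the same ceiling: the limit of > 50000 nM in this assay, at which 2 of the 3 values shown sit.

From the compounds shown here alone, whether the five-membered or the six-membered ring, or the hydroxy group on the former, matters in this assay therefore remains open, since any real difference would lie beyond the limit. Also open, going by these compounds, is whether a methyl ester in place of the carboxylic acid, or a plain piperidin-1-yl group with no carboxy group at all, would bring the reading back under the limit and yield a number that could be compared with that of the formyl compound.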